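The source may hold more compounds than are shown below. What is called first, only, known or untested is meant among the compounds shown, and "the series" means these compounds.

Three compounds have been measured in an assay for inhibition of inositol hexakisphosphate kinase 3 (Homo sapiens), read by colorimetric assay, coupled enzyme assay and malachite green, with a stated time of 120 min, in the presence of a further agent that is not named here; a higher number here means a weaker inhibitor, a lower number a stronger inhibitor:

compound 1, `O=C(O)/C=C/c1ccc2noc(-c3ccc(Oc4ccccc4)cc3)c2c1`, gives 760 nM
compound 2, `Cc1cccc(-c2onc3ccc(/C=C/C(=O)O)cc23)c1`, gives 3590 nM
compound 3, `O=C(O)c1ccc2noc(-c3ccc(Cc4ccccc4)cc3)c2c1`, gives 1290 nM

Among these three numbers, compound 3 has the second highest. Its nearest neighbour is compound 1, whose number is somewhat lower, yet the gap lies within the usual scatter of repeated measurements, so the two cannot be told apart. Compound 2 stands furthest away, with a number higher than that of compound 3 by more than the scatter.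

Compound 4, `O=C(O)c1ccc2noc(-c3ccc(Oc4ncc(Cl)cc4Cl)cc3)c2c1`, differs from compound 3 in one place: (3,5-dichloropyridin-2-yl)oxy in place of benzyl on an aromatic carbon. Going by the values given here, no measured pair shows this exact change, so its effect can only be estimated. Compound 1 carries a different group in the same part of the molecule and gives 760 nM in this assay, a number that sits within the scatter of the number for compound 3, which suggests that changes here have so far produced little movement. The step from compound 3 to compound 4 is therefore expected to be small, a 1.6-fold lower number from compound 3 to compound 4 (0.21 log units; within the scatter), leaning if anything towards a lower number. Compound 4 is expected to give about 800 nM, within 250 nM to 2500 nM.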

Compound 4, half-maximal inhibitory concentration: 2250 nM
Estimate against measurement, compound 4: 2.8-fold (0.45 log units) below; the range from low to high includes it.
By their numbers in this assay, from the lowest: compounds 1, 3, 4 and 2 (each within the scatter of the next, the first and the last beyond it).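

Going by these compounds alone, replacing benzyl with (3,5-dichloropyridin-2-yl)oxy gives a 1.7-fold higher number from compound 3 to compound 4 (0.24 log units; within the scatter), the first direct step at this place on the ring. A larger group, with a ring that holds a hetero atom and with two chlorine atoms, therefore leaves the number in a range that cannot be told apart from that of compound 3. No further evidence bears on this result.

The compounds shown leave open whether the ring nitrogen or the chlorine atoms matter on their own. From the compounds shown here alone, how an unsubstituted phenoxy group or an amine such as morpholine would fare at this place on the core of compound 3 also remains open.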